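Moving the ethyl group around the furan ring

The source may hold more compounds than are shown below. What is called first, only, known or untested is meant among the compounds shown, and "the series" means these compounds.

Of the compounds shown here, three sharing one core have been measured in an assay on CHO cells for displacement of a labelled ligand from C-X-C chemokine receptor type 1 (Homo sapiens); a higher number here means a weaker inhibitor, a lower number a stronger inhibitor. Compound 1 `CC[C@@H](Nc1c(Nc2cccc(C(=O)N(C)C)c2O)c(=O)c1=O)c1cc(C)cs1` gives 24 nM. Compound 2 `CC[C@@H](Nc1c(Nc2cccc(C(=O)N(C)C)c2O)c(=O)c1=O)c1cc(C)co1` gives 9 nM. Compound 3 `CCc1ccoc1[C@@H](CC)Nc1c(Nc2cccc(C(=O)N(C)C)c2O)c(=O)c1=O` gives 379 nM, the highest number of the three; it sits a 16-fold higher number from compound 1 to compound 3 (1.20 log units; beyond the scatter) and a 42-fold higher number from compound 2 to compound 3 (1.62 log units; beyond the scatter), both changes beyond the usual scatter, so compound 3 is the weakest inhibitor here.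

Compound 4 `CCc1coc([C@@H](CC)Nc2c(Nc3cccc(C(=O)N(C)C)c3O)c(=O)c2=O)c1` has not yet been measured. It differs from compound 3 in one place: 4-ethylfuran-2-yl in place of 3-ethylfuran-2-yl on a saturated chain carbon bound to a nitrogen on an aromatic ring and a saturated chain carbon. The two measured steps that bear on this are the ones into compound 3, since they show that a substituent at the 3-position of the furan goes with a much higher number than a methyl at the 4-position of the same furan in compound 2, or a methyl at the 4-position of the thiophene in compound 1. Compound 4 carries its ethyl at the 4-position, so a large drop in number is expected: a 15-fold lower number from compound 3 to compound 4 (1.18 log units; beyond the scatter). Compound 4 is therefore estimated at 25 nM, within a range of 8 nM to 80 nM.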

Compound 4, inhibition constant: 7 nM
The estimate for compound 4 lay 3.6-fold (0.55 log units) above the measured number, outside the stated range (below it).
By their numbers in this assay, from the lowest: compounds 4 and 2 (each within the scatter of the next); then compound 1; then compound 3.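

In this assay the same atoms, joined differently, give a 54-fold lower number from compound 3 to compound 4 (1.73 log units; beyond the scatter) and this separates two things that compound 3 left tied together: its ethyl differs from the methyl of compound 2 in both length and ring position, and now the high number goes with the 3-ethylfuran-2-yl placement rather than with the ethyl itself. At the 4-position, lengthening methyl to ethyl gives a 1.3-fold lower number from compound 2 to compound 4 (0.11 log units; within the scatter) so the two compounds cannot be told apart, whereas the step with a 3.4-fold lower number from compound 1 to compound 4 (0.54 log units; beyond the scatter) changes both the ring and the chain at once and cannot be credited to either. Nothing available explains why the ring position of the ethyl matters so much.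

The compounds shown leave open whether propyl or a longer chain in place of the ethyl of 4-ethylfuran-2-yl would keep the number this low. They also leave open how 4-ethylthiophen-2-yl would compare with the furan of compound 4.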